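Cyclopentyl for Trifluoromethyl in a Breast-Cancer Cell Series

A few compounds are considered here, and "the series" means these few. Any claim that something is new, unique, unknown or untested is made for them only; others in the source may bear on it.

Measured so far:
Compound 1, `O=C(O)/C=C/c1ccc(/C(=C(\c2ccccc2)C(F)F)c2ccc3[nH]ncc3c2)cc1`, 14 nM
Compound 2, `O=C(O)/C=C/c1ccc(/C(=C(\c2ccccc2)C(F)(F)F)c2ccc3[nH]ncc3c2)cc1`, 5.5 nM

Of the compounds shown here, two have been tested in a functional assay on MCF7 cells (Homo sapiens) for cytotoxicity, read by CellTiter-Glo, with a stated time of 5 days; on this read-out higher numbers stand for weaker inhibition and lower numbers for stronger inhibition. Compound 1 gives 14 nM and compound 2 gives 5.5 nM. For the measured compounds named here, the single measured step, a 2.5-fold lower number from compound 1 to compound 2 (0.41 log units; beyond the scatter), shows that the change went beyond the scatter. Compound 2 therefore stands lowest of the two numbers, with compound 1 as its nearest neighbour.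

Compound 3 is `O=C(O)/C=C/c1ccc(/C(=C(\c2ccccc2)C2CCCC2)c2ccc3[nH]ncc3c2)cc1`. It differs from compound 2 by cyclopentyl in place of trifluoromethyl on a double-bonded chain carbon bound to an aromatic carbon and a double-bonded chain carbon. Going by the values given here, no measured step involves a change of this kind: the one step on record concerns a fluoro in place of hydrogen on the same chain, not a carbocycle in place of trifluoromethyl. Among the compounds with values here, with no direct precedent, the expectation for compound 3 in this assay is a wide range around a modest rise in the number, a 1.8-fold higher number from compound 2 to compound 3 (0.26 log units; within the scatter). Compound 3 is thus estimated at 10 nM, with a range from 2.5 nM to 40 nM.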

Compound 3, half-maximal inhibitory concentration: 10 nM
Compound 3: the middle estimate sits on the measured number at the digits printed, within the range that was stated.
By their numbers in this assay, from the lowest: compounds 2, 3 and 1 (each within the scatter of the next, the first and the last beyond it).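

In this assay the step of a 1.8-fold higher number from compound 2 to compound 3 (0.26 log units; within the scatter) and the step of a 1.4-fold lower number from compound 1 to compound 3 (0.15 log units; within the scatter) both lie within the scatter, so at this place, on a double-bonded chain carbon bound to an aromatic carbon and a double-bonded chain carbon, cyclopentyl cannot be told apart from trifluoromethyl or difluoromethyl. The earlier pair showed only a change between two fluorinated groups, whereas compound 3 shows that a group without fluorine, and one carrying a ring of carbon only, can stand here with a number in the same range. No measurement in hand bears on why this is so.

The compounds shown leave open whether cyclopropyl, cyclohexyl or an open chain such as isopropyl would behave like cyclopentyl at this place. They also leave open whether a ring holding an amine or an ether oxygen would do so.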